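Swapping naphthalen-1-yl for 4-methoxyphenyl on compound 1

The source may report more compounds than this note shows. Statements on the series, on what has been measured and on what is new or still open speak of the compounds shown alone.

- Compound 1 `Cc1cc(Nc2ccn(Cc3cccc4ccccc34)n2)n2nc(SCc3ccc(Br)cc3)nc2n1` gives 5660 nM
- Compound 2 `Cc1cc(Nc2cc(C(C)(C)C)[nH]n2)n2nc(SCc3ccc(Br)cc3)nc2n1` gives 12400 nM
- Compound 3 `COc1ccc(CSc2nc3nc(C)cc(Nc4cc(-c5ccccc5)[nH]n4)n3n2)cc1` gives 8110 nM

These three numbers come from a functional assay on PC-9 cells (Homo sapiens) for inhibition, read by MTT assay, with a stated time of 72 h (a higher number here means a weaker inhibitor, a lower number a stronger inhibitor), and they are all that is known so far. Compound 1 sits at the low end of the set, together with compound 3, since the two lie within the scatter of each other. Compound 2 has a higher number than compound 1, and that gap lies beyond the scatter.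

The next compound to be read is compound 4 `COc1ccc(Cn2ccc(Nc3cc(C)nc4nc(SCc5ccc(Br)cc5)nn34)n2)cc1` which keeps the core of compound 1 and changes one group 4-methoxyphenyl in place of naphthalen-1-yl on a saturated chain carbon bound to an aromatic nitrogen with 4-methoxyphenyl in place of naphthalen-1-yl on a saturated chain carbon bound to an aromatic nitrogen.

Within the data shown here, no two measured compounds differ in only one place, so no direct step can guide the expectation. The measured set is narrow, though: in this assay compound 1 gives 5660 nM and compound 2 gives 12400 nM so the gap between them lies only just beyond the scatter, and no change beyond the scatter is expected here, in either direction. The estimated size of a 1.2-fold higher number from compound 1 to compound 4 (0.09 log units; within the scatter) is small, with a slight lean towards a higher number. The estimated value for compound 4 is 7000 nM as the middle of the range.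
The expected range for compound 4 runs from 3000 nM to 16000 nM in this estimate.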

Compound 4, half-maximal inhibitory concentration: > 50000 nM
Compound 4: a limit, no number; the forecaster's own chance of this, stated with the estimate: 5%; middle value at least 7.1-fold (0.85 log units) from the limit.
By their numbers in this assay, from the lowest: compounds 1, 3 and 2 (each within the scatter of the next, the first and the last beyond it). At a limit, above all of these: compound 4.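

In this assay compound 4 gives > 50000 nM, which is a limit of the assay and not a number. Among these compounds, the result shows that the group on a saturated chain carbon bound to an aromatic nitrogen matters: 4-methoxyphenyl in place of naphthalen-1-yl brings an at least 8.8-fold higher number from compound 1 to compound 4 (0.94 log units; beyond the scatter), and the earlier compounds, none of which differed in only one place, could not show such a step. The step can be read only as a minimum, and its full size stays unknown: the limit of > 50000 nM in this assay, at which 1 of the 4 values shown sits.

The change replaces two six-membered aromatic rings of carbon only with one and also brings in an oxygen, so this single step does not separate the loss of the second ring from the arrival of the methoxy group. The compounds shown leave open whether an unsubstituted phenyl, a 4-chlorophenyl or a naphthalen-2-yl on that chain carbon would read close to compound 1 or reach the limit seen for compound 4.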